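Enantiomer swap at a trifluoromethyl carbinol stereocentre

The source may report more compounds than this note shows. Statements on the series, on what has been measured and on what is new or still open speak of the compounds shown alone.

Measured compounds:
compound 1, `c1ccc2c(N3CCC4(CCCCC4)CC3)cncc2c1`, 554 nM
compound 2, `c1ccc2c(N3CCC4(CCCO4)CC3)cncc2c1`, 704 nM
compound 3, `CN1CC2(CCN(c3cncc([C@](C)(O)C(F)(F)F)c3)CC2)CC1=O`, 32 nM

In an assay on V79 cells for inhibition of cytochrome P450 11B2, mitochondrial (Homo sapiens), read by HTRF, with stated times of 1 h and 3 h (on this read-out lower numbers stand for stronger inhibition and higher numbers for weaker inhibition), compound 3 gives the lowest of the three numbers, well apart from the other two. Compound 1 sits at 554 nM and compound 2 at 704 nM, both beyond the scatter from compound 3 in this assay; the two of them lie within the scatter of each other, so nothing separates them.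

Compound 4, `CN1CC2(CCN(c3cncc([C@@](C)(O)C(F)(F)F)c3)CC2)CC1=O`, is the mirror partner of compound 3: the two compounds have the same atoms and bonds and differ only in configuration as drawn: 1 of 1 stereo elements differ; a stereocentre at a saturated chain carbon is drawn S in compound 3 and R in compound 4. Nothing else changes; the same atoms and bonds are present, and only the configuration at that carbinol carbon is drawn the other way round.

No measured pair among these compounds differs in configuration alone, so the size of such a step cannot be read off the numbers shown. Where a single stereocentre carries a hydroxyl and a trifluoromethyl group next to a ring, the two configurations are usually not equal in this assay, and the one already measured is potent. Compound 4 is therefore expected to show a weaker value, estimated at 250 nM, within a broad range from 60 nM to 1200 nM. The expected step from compound 3 to compound 4 is a 7.8-fold higher number from compound 3 to compound 4 (0.89 log units; beyond the scatter), a loss that should exceed the scatter.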

Compound 4, half-maximal inhibitory concentration: 448 nM
Compound 4: the middle estimate sits 1.8-fold (0.25 log units) below what was measured; low and high end bracket the measured number.
By their numbers in this assay, from the lowest: compound 3; then compounds 4, 1 and 2 (each within the scatter of the next).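

Inverting the carbinol carbon gives a 14-fold higher number from compound 3 to compound 4 (1.15 log units; beyond the scatter) in this assay, the first step in this set that can be read at a single place, as compounds 1 and 2 offered no such comparison. The whole of this step can be assigned to the configuration at that one carbon, because nothing else separates the pair: the fact that compounds 3 and 4 differ only in the configuration as drawn. At this position, then, the same groups do not give the same result in both arrangements, and the configuration drawn S gives the lower number in this assay.

The compounds shown leave open how much of this gap between configurations depends on the hydroxyl and how much on the trifluoromethyl group, for instance whether it would persist with a methoxy group in place of the hydroxyl or a difluoromethyl group in place of the trifluoromethyl. Also open, as far as these compounds go, is whether a gap of this size would appear with the same carbinol carbon on a different core, such as the core of compound 1.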